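The source may hold more compounds than are shown below. What is called first, only, known or untested is meant among the compounds shown, and "the series" means these compounds.

Measured so far:
- compound 1, `COc1cc(OCc2cccc(CCc3ccccc3)c2)c2cc(-c3cn4nc(OC)sc4n3)oc2c1`, in an ADME assay on microsomes from liver (Homo sapiens) for metabolic stability, with a stated time of 10 min (a higher number here means that more of the compound is left, a lower number that less of the compound is left), compound 1 gives 99%
- compound 2, `COc1nn2cc(-c3cc4cccc(OC)c4o3)nc2s1`, in this assay compound 2 gives 25%

Going by the values given here, of the two numbers, compound 1 stands highest; compound 2 is the only other compound, and its value lies below that of compound 1 by a margin well beyond the scatter of this assay. Among the compounds with values here, no step between these two is given, so only the two values themselves can be compared, and they share the core but differ in more than one place.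

Compound 3, `COc1cc(OCc2cccc(OCc3ccccc3)c2)c2cc(-c3cn4nc(OC)sc4n3)oc2c1`, has not yet been measured. It differs from compound 1 by one change: benzyloxy in place of phenethyl on an aromatic carbon. Within the data shown here, for such a change no comparable step among the measured compounds exists, so the size of the step rests on the starting point alone. Since compound 1 already gives 99% in this assay, little room remains upward, and the expectation is a step that is either none beyond the scatter or slightly downward.

Compound 3 is therefore estimated to give 92% in this assay, within a range from 75% to 100%. The expected step is a number 7 percentage points lower from compound 1 to compound 3 (within the scatter).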

Compound 3, percent of the compound remaining: 85%
Estimate against measurement, compound 3: 7 percentage points above; the range from low to high includes it.
By their numbers in this assay, from the lowest: compound 2; then compound 3; then compound 1.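

The change to benzyloxy in place of phenethyl on an aromatic carbon, meta to a large group, gives a number 14 percentage points lower from compound 1 to compound 3 (beyond the scatter) in this assay. Going by these compounds alone, this is the first one-place comparison, and it shows that the group at this position can affect the percent of compound remaining, even when both groups hold 8 heavy atoms and one six-membered aromatic ring of carbon only. The two groups differ in that benzyloxy carries an oxygen and a hydrogen-bond acceptor while phenethyl carries neither, but no measurement at hand bears on why the number falls, so the step stands as an observation without an explanation.

A single step cannot separate the contribution of the oxygen from that of the rest of the benzyloxy group, and it cannot show whether the same change would give a similar step on a different core. From the compounds shown here alone, how an amine, a carboxylic acid or a longer chain such as phenylpropyl at this position would compare with phenethyl and benzyloxy also remains open.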